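From isobutyl to cyclohexyl on a shared core

This account rests on a few compounds, and the source may have more. Where it says the series, first, only, none or still open, it means among the compounds named here.

Two compounds have so far been examined in a toxicity assay on Vero cells (Chlorocebus sabaeus) for cytotoxicity, read by MTT assay, with a stated time of 72 h (a lower number here means a stronger inhibitor, a higher number a weaker inhibitor), and neither yields a number. Compound 1 (`CC(C)(C)c1nc2ccccc2n1C(=O)c1cccc2ccccc12`) gives > 10000 nM in this assay, which is a limit of the assay. Compound 2 (`COc1ccc(C(=O)n2c(CC(C)C)nc3ccccc32)cc1`) gives > 10000 nM in this assay, which is likewise a limit. Going by the values given here, compound 2 thus sits with the only other tested compound at the limit of > 10000 nM in this assay, at which 2 of the 2 values shown sit, and has no measured value of its own.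

Compound 3 (`COc1ccc(C(=O)n2c(C3CCCCC3)nc3ccccc32)cc1`) differs from compound 2 in one place, with cyclohexyl in place of isobutyl on an aromatic carbon, between two ring nitrogen atoms (cyclohexyl in place of isobutyl on an aromatic carbon). Among the compounds with values here, no pair of measured compounds differs in one place, so the size of this step has no direct precedent. Within the data shown here, both compounds tested so far reach the limit, so no step beyond the scatter is expected in this assay, and the result will most likely be a limit again. The expected change is a step that the limit leaves unreadable from compound 2 to compound 3 and remains only an estimate. For compound 3 the estimated value is 15000 nM (expected range 6000 nM to 40000 nM) in this assay, pending measurement.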

Compound 3, half-maximal inhibitory concentration: 1640 nM
Beside the measured number, compound 3's estimate is 9.1-fold (0.96 log units) above it, outside the stated range (below it).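

Going by these compounds alone, compound 3 is the first compound in this assay to give a number rather than a limit, which shows that the group on this aromatic carbon, between two ring nitrogen atoms, can move the read-out on this shared core. Placing cyclohexyl, with its six-membered non-aromatic ring of carbon only, where isobutyl stood gives an at least 6.0-fold lower number from compound 2 to compound 3 (0.78 log units; beyond the scatter), a step beyond the scatter. This is a lower bound on the step and not its full size, because compound 2 has only a limit and no value of its own: the limit of > 10000 nM in this assay, at which 2 of the 3 values shown sit.

With a single step at this position, the compounds shown cannot tell whether the lower number goes with the ring itself or with the added carbon atoms, and a hexyl chain or a phenyl ring in the same place would separate the two. They also leave open whether the number would hold with an amine on the cyclohexyl ring, or whether the methoxy group on the other side of the carbonyl plays any part in it.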